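Phenyl to 4-methylphenyl at the assay limit

The compounds below may be only part of what the source reports. "The series", "measured", "known", "first", "only" and "open" are said of these compounds alone.

In an ADME assay on RAW264.7 cells (Mus musculus) for cytotoxicity, read by MTT assay, with a stated time of 48 h (a higher number here means a weaker inhibitor, a lower number a stronger inhibitor), compound 2 (`O=C(NCCOC(=S)Nc1ccccc1)c1cccnc1`) gives > 800000 nM as a limit and not a number. Compound 1 (`CC(C)(Oc1ccc(Cl)cc1)C(=O)NCCOC(=S)Nc1ccc(F)cc1`) gives > 800000 nM as a limit too. Compound 3 (`CC(C)(Oc1ccc(Cl)cc1)C(=O)OCCCOC(=O)CCCCC1CCSS1`) gives > 800000 nM as a limit too. Among the compounds with values here, no measured step exists yet, and the series shows only the limit of > 800000 nM in this assay, at which 3 of the 3 values shown sit, here. Compound 4 (`Cc1ccc(NC(=S)OCCNC(=O)c2cccnc2)cc1`) has methyl in place of hydrogen on an aromatic carbon para to a large group. The expectation in this assay rests on compound 2 at > 800000 nM as a limit, and no change beyond the scatter is expected. The expected step of a number no higher from compound 2 to compound 4 (the limit leaves the size open) is an estimate only. For compound 4 the estimated value is 800000 nM with an expected range from 400000 nM to 1600000 nM for this compound.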

Compound 4, half-maximal inhibitory concentration: > 800000 nM
Compound 4: only a limit was reported; the forecaster's own chance of this, stated with the estimate: 75%; the middle value lies on the limit itself.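

Compound 2 and compound 4 both stand only as limits, and no step can be read between them. Any effect of methyl in place of hydrogen on an aromatic carbon stays open, as does any ranking within the series: the limit of > 800000 nM in this assay, at which 4 of the 4 values shown sit.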